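Cyclopropylsulfamoyl in place of cyclobutylsulfonyl on the aryl sulfonyl

A few compounds are considered here, and "the series" means these few. Any claim that something is new, unique, unknown or untested is made for them only; others in the source may bear on it.

The series shares a core in which a proline-type amide carries an aryl sulfonyl group bearing a second sulfonyl substituent; the compounds are compared in a functional assay on MIA PaCa-2 cells (Homo sapiens) for inhibition, read by MTT assay, with a stated time of 7 days; a lower number here means a stronger inhibitor, a higher number a weaker inhibitor. Compound 1 `CCN1CC(NC(=O)[C@@H]2CCCN(S(=O)(=O)c3ccc(S(=O)(=O)N(CC)CC)cc3)C2)C1` returns only a limit, > 30000 nM, and no number. Compound 2 `CC(C)c1noc(C2CCN(C(=O)[C@@H]3CCCN(S(=O)(=O)c4ccc(S(=O)(=O)C(C)C)cc4)C3)CC2)n1` gives 50 nM in this assay. Compound 3 `CC(C)c1noc(N2CCN(C(=O)[C@@H]3CCCN(S(=O)(=O)c4ccc(S(=O)(=O)C5CCC5)cc4)C3)CC2)n1` gives 70 nM in this assay, close to the value of compound 2 and within the usual scatter of it, so the two cannot be ordered against each other.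

The step to compound 4 `CC(C)c1noc(N2CCN(C(=O)[C@@H]3CCCN(S(=O)(=O)c4ccc(S(=O)(=O)NC5CC5)cc4)C3)CC2)n1` consists of cyclopropylamino in place of cyclobutyl on a sulfonyl sulfur. The change keeps the group small but swaps a carbocycle for a ring joined through a nitrogen carrying a hydrogen. No measured step of this kind exists in the set, so the expectation rests on the tolerance shown by compounds 2 and 3 for different small groups on that sulfonyl sulfur. A modest loss is expected for compound 4, the step from compound 3 being estimated at a 2.1-fold higher number from compound 3 to compound 4 (0.33 log units; beyond the scatter). Compound 4 is therefore expected to give about 150 nM in this assay, with a plausible range from 40 nM to 800 nM.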

Compound 4, half-maximal inhibitory concentration: 1000 nM
Estimate against measurement, compound 4: 6.7-fold (0.82 log units) below, and the stated range ends below it.
By their numbers in this assay, from the lowest: compounds 2 and 3 (each within the scatter of the next); then compound 4. At a limit, above all of these: compound 1.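

In this assay, the sulfonyl sulfur whose other neighbour is an aromatic carbon proves sensitive to the exchange of cyclobutyl for cyclopropylamino, with a 14-fold higher number from compound 3 to compound 4 (1.15 log units; beyond the scatter). This is the only step in the series shown that differs in one place, and it is large even though both groups have the same number of heavy atoms, so heavy-atom count alone does not preserve the value at this position. The exchange brings in a nitrogen and a hydrogen-bond donor and replaces a four-membered ring with a three-membered one, but no measurement at hand explains the loss.

Ring size and the nitrogen change together in this single step, so their separate contributions cannot be read from compounds 3 and 4. A cyclopropyl group bonded directly to the sulfonyl sulfur would isolate the ring change against compound 3, while a cyclobutylamino group would isolate the entry of the nitrogen, and an N-methyl-N-cyclopropylamino group would test the same position without the hydrogen on that nitrogen.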